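Thiophen-3-yl in place of 2-phenylethenyl: working notes

The compounds below may be only part of what the source reports. "The series", "measured", "known", "first", "only" and "open" are said of these compounds alone.

- compound 1 `C(=C/c1nc2ccccn2c1Sc1ccccc1)\c1ccccc1`: 22000 nM
- compound 2 `Cc1ccc(-c2nc3ccc(C)cn3c2Sc2ccccc2)cc1`: 57700 nM

Both values come from a functional assay on DU-145 cells (Homo sapiens) for inhibition, read by MTT assay, with a stated time of 48 h; a lower number here means a stronger inhibitor, a higher number a weaker inhibitor. Compound 1 holds the lower number of the two, and the gap to compound 2 lies beyond the usual scatter. Compound 3 `c1ccc(Sc2c(-c3ccsc3)nc3ccccn23)cc1` is the next case, with thiophen-3-yl in place of 2-phenylethenyl on an aromatic carbon. Among the compounds with values here, no measured pair isolates a change at this place, so the expectation is loose: a small move toward a higher number, probably not beyond the scatter. The expected change is a 1.4-fold higher number from compound 1 to compound 3 (0.13 log units; within the scatter). For compound 3 the estimated value is 30000 nM, with an expected range of 12000 nM to 75000 nM.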

Compound 3, half-maximal inhibitory concentration: 85900 nM
Compound 3: middle estimate off by 2.9-fold (0.46 log units), on the low side; the whole stated range lies below it.
By their numbers in this assay, from the lowest: compound 1; then compounds 2 and 3 (each within the scatter of the next).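

In this assay, within the data shown here, thiophen-3-yl in place of 2-phenylethenyl gives a 3.9-fold higher number from compound 1 to compound 3 (0.59 log units; beyond the scatter), the first single-place step. The aromatic carbon bearing these groups is therefore not indifferent to the group it carries, although the step is modest. Nothing available accounts for the size or direction of this step.

A single replacement cannot separate the loss of the double bond from the exchange of the six-membered ring for the five-membered one. As far as these compounds go, a 2-phenylethyl group or an aminomethyl group at this place would test these contributions, and how either would read remains open.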